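The source may report more compounds than this note shows. Statements on the series, on what has been measured and on what is new or still open speak of the compounds shown alone.

Among the compounds with values here, in a functional assay on MDA-MB-231 cells (Homo sapiens) for cytotoxicity, read by MTT assay, with a stated time of 72 h (on this read-out lower numbers stand for stronger inhibition and higher numbers for weaker inhibition), compound 1 (`O=C1c2c[n+]([O-])c3ccccc3c2C(=O)c2c1c1ccccc1n2CCCCN1CCNCC1`) gives 3310 nM as its reading, the higher of the two numbers measured so far. Compound 2 (`O=C1c2c[n+]([O-])c3ccccc3c2C(=O)c2c1c1ccccc1n2Cc1cn([C@H]2C[C@H](O)[C@@H](CO)O2)nn1`) gives 580 nM in this assay and carries a different side chain on the same core.

Compound 3 (`CN1CCN(CCCCCCn2c3c(c4ccccc42)C(=O)c2c[n+]([O-])c4ccccc4c2C3=O)CC1`) has not yet been measured. It keeps the core of compound 1 and changes only the side chain, and 2-(4-methylpiperazin-1-yl)ethyl in place of piperazin-1-yl on a saturated chain carbon, four bonds along the chain from an aromatic nitrogen is the counted difference: 2-(4-methylpiperazin-1-yl)ethyl in place of piperazin-1-yl on a saturated chain carbon, four bonds along the chain from an aromatic nitrogen. Read one bond further out, 3-(piperazin-1-yl)propyl becomes 5-(4-methylpiperazin-1-yl)pentyl. The six-membered non-aromatic ring remains, now further along the chain.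

Within the data shown here, no measured pair of compounds isolates such a change, so its effect cannot be read from the data. With compound 1 at 3310 nM as the closest reference, no shift beyond the scatter is expected in this assay for this change. The estimated move (a 1.3-fold lower number from compound 1 to compound 3 (0.12 log units; within the scatter)) points slightly toward a lower number. The estimated value for compound 3 is 2500 nM with an expected range from 800 nM to 6500 nM as its upper end.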

Compound 3, half-maximal inhibitory concentration: 2400 nM
For compound 3 the middle estimate is 1.0-fold (0.02 log units) above the measured one; the measured number falls inside the stated range.
By their numbers in this assay, from the lowest: compound 2; then compounds 3 and 1 (each within the scatter of the next).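

In this assay, putting 2-(4-methylpiperazin-1-yl)ethyl in place of piperazin-1-yl on a saturated chain carbon, four bonds along the chain from an aromatic nitrogen, gives a 1.4-fold lower number from compound 1 to compound 3 (0.14 log units; within the scatter). This position therefore accepts a larger side chain in this assay with no shift beyond the scatter, even though the six-membered non-aromatic ring now sits further along the chain and the group has 0 hydrogen-bond donors in place of 1. The chain extension and the added methyl arrive together, so this single step cannot show what each does alone, and no measurement at hand offers an explanation for the result.

Still open, from the compounds shown here alone, is whether the two parts of the change would each leave the reading within the scatter if taken separately, or whether they offset each other, which a 4-methylpiperazin-1-yl group on the shorter chain or a piperazin-1-yl group on the longer chain could test. Going by these compounds, it also remains open whether a different end group on the chain, such as morpholine or a dimethylamino group, or a still longer chain, would read differently in this assay.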